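A few compounds are considered here, and "the series" means these few. Any claim that something is new, unique, unknown or untested is made for them only; others in the source may bear on it.

In a functional assay on RAW264.7 cells (Mus musculus) for inhibition, read by Griess assay, with stated times of 1 h and 24 h (a higher number here means a weaker inhibitor, a lower number a stronger inhibitor), compound 1 `COc1cc(OC)c2c(c1)C(C(O)c1ccc(O)cc1)OC2=O` reaches only a limit, > 10000 nM. Compound 2 `CCC(C)Oc1ccc(C(O)C2OC(=O)c3c(OC)cc(OC)cc32)cc1`, which has sec-butyl in place of hydrogen on an oxygen on an aromatic ring, also reaches only a limit, > 10000 nM. Compound 3 `COc1cc(OC)c2c(c1)C(C(O)c1ccc(OCCOc3ccccc3)cc1)OC2=O`, with 2-phenoxyethyl there instead, again gives only a limit, > 10000 nM. Going by the values given here, the series so far therefore stands at the limit of > 10000 nM in this assay, at which 3 of the 3 values shown sit.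

Compound 4 `COc1cc(OC)c2c(c1)C(C(O)c1ccc(OCc3ccc(Cl)cc3)cc1)OC2=O` replaces phenoxymethyl with 4-chlorophenyl on a saturated chain carbon bound to an oxygen on an aromatic ring (4-chlorophenyl in place of phenoxymethyl on a saturated chain carbon bound to an oxygen on an aromatic ring), turning 2-phenoxyethyl into 4-chlorobenzyl. Among the compounds with values here, three measured steps bear on this change: a step that the two limits leave unreadable from compound 1 to compound 2, a step that the two limits leave unreadable from compound 1 to compound 3 and a step that the two limits leave unreadable from compound 2 to compound 3. None offers a size or direction to carry over, so no shift beyond the scatter is expected. The estimated step is a step that the limit leaves unreadable from compound 3 to compound 4. For compound 4 the estimate is 12000 nM, with an expected range from 3000 nM to 40000 nM.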

Compound 4, half-maximal inhibitory concentration: 4320 nM
Estimate against measurement, compound 4: 2.8-fold (0.44 log units) above, within the range that was stated.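

At this oxygen on an aromatic ring, 4-chlorobenzyl gives the only readable value among the compounds shown: this assay records an at least 2.3-fold lower number from compound 3 to compound 4 (0.36 log units; beyond the scatter). Against sec-butyl the same group gives an at least 2.3-fold lower number from compound 2 to compound 4 (0.36 log units; beyond the scatter), and against hydrogen it gives an at least 2.3-fold lower number from compound 1 to compound 4 (0.36 log units; beyond the scatter). The group at this place can therefore move the number, but each step has only a lower bound on its size because the other three values are limits: the limit of > 10000 nM in this assay, at which 3 of the 4 values shown sit.

Whether the chlorine matters remains open, since no plain benzyl is among these compounds. Going by these compounds, how an amine or a carboxylic acid on the benzyl ring would read also remains unknown.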